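The source may hold more compounds than are shown below. What is called first, only, known or untested is meant among the compounds shown, and "the series" means these compounds.

Compound 2, `Oc1cc(C(F)(F)F)ccc1-c1nc(-c2ccccc2O)n(-c2ccc(F)cc2)n1`, gives 67.2% in a functional assay on PC-12 cells (Rattus norvegicus) for cytotoxicity, read by MTT assay, with stated times of 2 h and 24 h, tested at 1 uM; a lower number here means a weaker effect, a higher number a stronger effect of the compound at the concentration tested. Its two neighbours on that scale are compound 1, `CCc1ccc(-n2nc(-c3ccc(C(F)(F)F)cc3O)nc2-c2ccccc2O)cc1`, at 64.4%, and compound 3, `Oc1cc(C(F)(F)F)ccc1-c1nc(-c2ccccc2O)n(-c2ccc(I)cc2)n1`, at 70.1%. The steps separating them are small: a number 2.8 percentage points higher from compound 1 to compound 2 (within the scatter), a number 2.9 percentage points higher from compound 2 to compound 3 (within the scatter) and a number 5.7 percentage points higher from compound 1 to compound 3 (within the scatter), so all three numbers sit within the scatter of one another and none can be called stronger or weaker than the rest.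

Compound 4, `COc1ccc(-n2nc(-c3ccc(C(F)(F)F)cc3O)nc2-c2ccccc2O)cc1`, differs from compound 2 in one place: methoxy in place of fluoro on an aromatic carbon. Among the measured compounds shown here, the steps that bear on this are the two exchanges at the same aromatic carbon, a number 2.8 percentage points higher from compound 1 to compound 2 (within the scatter) and a number 2.9 percentage points higher from compound 2 to compound 3 (within the scatter), both within the scatter. Three different groups at that carbon have therefore left this assay essentially unchanged, and a methoxy there is expected to do the same: the estimated step is a number 0.2 percentage points lower from compound 2 to compound 4 (within the scatter), nothing beyond the scatter. Compound 4 is thus expected to give about 67%, in the range 57% to 77%.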

Compound 4, a percentage reported as activity, at one concentration (the size of the read-out at that concentration, not a potency): 69%
Compound 4: middle estimate off by 2 percentage points, on the low side; low and high end bracket the measured number.
By their numbers in this assay, from the lowest: compounds 1, 2, 4 and 3 (each within the scatter of the next).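

In this assay the exchange to methoxy gives a number 1.8 percentage points higher from compound 2 to compound 4 (within the scatter) and a number 1.1 percentage points lower from compound 3 to compound 4 (within the scatter) and a number 4.6 percentage points higher from compound 1 to compound 4 (within the scatter) so the 4-methoxyphenyl compound cannot be separated from any of the other three. The flat result at this aromatic carbon, para to a large group, now extends to a group with one hydrogen-bond acceptor where fluoro has none, so that count does not separate the compounds in this set. No measurement at hand accounts for this flatness.

Going by these compounds, whether an amine, a carboxylic acid or a longer chain at this carbon would stay within the same narrow band remains open. On these data alone, all four compounds share the same core with its trifluoromethyl and hydroxyl groups, so what changes at those places would do also remains unknown.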